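This account rests on a few compounds, and the source may have more. Where it says the series, first, only, none or still open, it means among the compounds named here.

Compound 1 `Nc1nc(NCc2ccccc2)c2ncn(/C=C3/CC3(CO)CO)c2n1` and compound 2 `Nc1nc(NC2CCCCC2)c2ncn(/C=C3/CC3(CO)CO)c2n1` are the measured pair. In an ADME assay on CCRF-HSB-2 cells (Homo sapiens) for cytotoxicity, with a stated time of 7 days (a lower number here means that less compound is tolerated, a higher number that more compound is tolerated), compound 1 gives > 20000 nM, which is a limit of the assay. In this assay compound 2 gives > 20000 nM, again a limit. The step that the two limits leave unreadable from compound 1 to compound 2 therefore cannot be sized, and compound 2 stands only at the limit of > 20000 nM in this assay, at which 2 of the 2 values shown sit. Compound 3 `CCCCSc1nc(N)nc2c1ncn2/C=C1/CC1(CO)CO` carries butylsulfanyl in place of cyclohexylamino on an aromatic carbon. Going by the values given here, no measured step bears on this change, so no shift beyond the scatter in this assay is expected. Compound 3 is estimated at 30000 nM, in a range from 10000 nM to 100000 nM, which means an expected step that the limit leaves unreadable from compound 2 to compound 3.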

Compound 3, half-maximal cytotoxic concentration: 89000 nM
Estimate against measurement, compound 3: 3.0-fold (0.47 log units) below, within the range that was stated.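

The size of the step from compound 1 or compound 2 to compound 3 cannot be read, because compounds 1 and 2 give only a limit: the limit of > 20000 nM in this assay, at which 2 of the 3 values shown sit. The compounds shown leave open how far benzylamino, cyclohexylamino and butylsulfanyl really differ in this assay.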